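Swapping the Amide Tail: Methylamino to Morpholine

The source may report more compounds than this note shows. Statements on the series, on what has been measured and on what is new or still open speak of the compounds shown alone.

Compound 1 `CCCCCCCCN(C)C(=O)Cn1cc(Cc2cnc(O)nc2)c(=O)nc1SCc1ccc(F)cc1` gives 66% in a functional assay on a cell-free system (plasma) for inhibition of platelet-activating factor acetylhydrolase (Homo sapiens), tested at 100 nM; on this read-out higher numbers stand for more inhibition at the one concentration tested (going by the name of the read-out) and lower numbers for less inhibition. Compound 2 `CCCCCCCCN(C)C(=O)Cn1cc(Cc2cnc(=O)n(C)c2)c(=O)nc1SCc1ccc(F)cc1` gives 55%. Compound 3 `CCCCCCCCN(C)C(=O)Cn1cc(Cc2cnc(=O)n(CC(=O)NC)c2)c(=O)nc1SCc1ccc(F)cc1` gives 63%.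

Compound 3 stands second of the three numbers, though the distance to both neighbours is small: a number 3 percentage points lower from compound 1 to compound 3 (within the scatter), and a number 8 percentage points higher from compound 2 to compound 3 (within the scatter). Compound 4 `CCCCCCCCN(C)C(=O)Cn1cc(Cc2cnc(=O)n(CC(=O)N3CCOCC3)c2)c(=O)nc1SCc1ccc(F)cc1` differs from compound 3 in one place: morpholin-4-yl in place of methylamino on a carbonyl carbon. Among the measured compounds shown here, the only measured step that touches this part of the molecule is the one that added the methylcarbamoyl group, from compound 2 to compound 3, and it stayed within the scatter. For the measured compounds named here, no measured pair changes the amide substituent itself, so the expected step is a number 3 percentage points lower from compound 3 to compound 4 (within the scatter), that is, none beyond the scatter. Compound 4 is therefore estimated to give 60%, with a range from 45% to 75%.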

Compound 4, a percentage reported as inhibition, at one concentration (the size of the read-out at that concentration, not a potency): 64%
Estimate against measurement, compound 4: 4 percentage points below; measured number inside the range.
By their numbers in this assay, from the lowest: compounds 2, 3, 4 and 1 (each within the scatter of the next, the first and the last beyond it).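

With morpholin-4-yl in place of methylamino on the carbonyl carbon, the amide itself changes for the first time among these compounds, and the amide hydrogen is lost, giving a number 1 percentage points higher from compound 3 to compound 4 (within the scatter) in this assay. Set against hydrogen on the saturated chain carbon, the whole (morpholin-4-yl)carbonyl group gives a number 9 percentage points higher from compound 2 to compound 4 (within the scatter), so neither the new ring nor the group as a whole shifts the number beyond the scatter. No evidence is available to explain these results.

Going by these compounds, whether a piperazin-1-yl amine on this carbonyl carbon, or a carboxylic acid in place of the amide, would shift the number beyond the scatter remains open.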